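The source may hold more compounds than are shown below. What is called first, only, known or untested is meant among the compounds shown, and "the series" means these compounds.

Measured compounds in a functional assay on B16-F10 cells (Mus musculus) for inhibition, read by MTT assay, with a stated time of 48 h; a higher number here means a weaker inhibitor, a lower number a stronger inhibitor:
compound 1 `COc1ccc(/C=C/c2cc(OC)cc(OC)c2/C=C/C(=O)N2CCCCC2C)cc1` gives 7660 nM
compound 2 `COc1ccc(/C=C/c2cc(OC)cc(OC)c2/C=C/C(=O)N2CCCC2)cc1` gives 9280 nM

Compound 2 holds the higher of the two numbers recorded so far, with compound 1 nearest; the step of a 1.2-fold higher number from compound 1 to compound 2 (0.08 log units; within the scatter) stays within the scatter, so no order between the two can be read from these values. Both share the same core and differ only in the ring attached at the carbonyl carbon.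

Compound 3 `COc1ccc(/C=C/c2cc(OC)cc(OC)c2/C=C/C(=O)N2CCC(c3ccccc3)CC2)cc1` is the next member. Its change from compound 2 is 4-phenylpiperidin-1-yl in place of pyrrolidin-1-yl on a carbonyl carbon. For the measured compounds named here, the only measured step touching this position is a 1.2-fold higher number from compound 1 to compound 2 (0.08 log units; within the scatter), a swap of one saturated nitrogen ring for another, and it did not move the number beyond the scatter. The entering group of compound 3 is larger than either ring seen so far and carries an additional aromatic ring, for which no comparison exists in the series; the available evidence therefore gives no direction, and no step beyond the scatter in this assay is expected from compound 2 to compound 3. Compound 3 is estimated at 8000 nM in this assay, in the range 3500 nM to 18000 nM, a step of a 1.2-fold lower number from compound 2 to compound 3 (0.06 log units; within the scatter) that is taken to be within the scatter.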

Compound 3, half-maximal inhibitory concentration: 9180 nM
Beside the measured number, compound 3's estimate is 1.1-fold (0.06 log units) below it; the measured number falls inside the stated range.
By their numbers in this assay, from the lowest: compounds 1, 3 and 2 (each within the scatter of the next).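

In this assay, 4-phenylpiperidin-1-yl in place of pyrrolidin-1-yl on a carbonyl carbon gives a 1.0-fold lower number from compound 2 to compound 3 (0.00 log units; within the scatter) and so leaves no measurable difference, while 4-phenylpiperidin-1-yl in place of 2-methylpiperidin-1-yl gives a 1.2-fold higher number from compound 1 to compound 3 (0.08 log units; within the scatter) and likewise stays within the scatter. For the compounds shown here, the earlier pair compared only two saturated nitrogen rings, whereas this position now also tolerates a larger group with an added six-membered aromatic ring of carbon only, and all three compounds lie within the scatter of one another. In this series, the number in this assay therefore does not separate these three groups on the carbonyl carbon, and no data at hand offer a reason for this result.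

Still open, from the compounds shown here alone, is whether any group at this position can move the number beyond the scatter, for example piperazin-1-yl, a piperidine ring carrying a carboxylic acid, or an open-chain dimethylamino group. The compounds shown also leave open how changes to the shared core, such as replacing a methoxy group with a hydroxyl group, would compare with these amide changes.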